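Changing the oxane of compound 2 to a piperidine

This account rests on a few compounds, and the source may have more. Where it says the series, first, only, none or still open, it means among the compounds named here.

Compound 2 `c1ccc2c(c1)CN[C@@H](CN(CCCCNC1CCOCC1)[C@H]1CCCc3cccnc31)C2` is one of two measured compounds; in a functional assay on cells for antagonist activity at C-X-C chemokine receptor type 4 (Homo sapiens), read by fluorescence and calcium flux, with stated times of 25 min and 90 s (a higher number here means a weaker inhibitor, a lower number a stronger inhibitor), compound 2 gives 29.4 nM, and compound 1 `c1ccc2c(c1)CN[C@@H](CN(CCCCNCC1CCOCC1)[C@H]1CCCc3cccnc31)C2` gives 52.9 nM. For the measured compounds named here, the only measured step, a 1.8-fold lower number from compound 1 to compound 2 (0.26 log units; within the scatter), concerns the same amine nitrogen but a different change. Compound 3 `c1ccc2c(c1)CN[C@@H](CN(CCCCNC1CCNCC1)[C@H]1CCCc3cccnc31)C2` differs from compound 2 by piperidin-4-yl in place of oxan-4-yl on an amine nitrogen. Going by the values given here, no measured step bears on this exchange, so the expectation rests on the position alone: compound 3 is expected to show a 2.0-fold lower number from compound 2 to compound 3 (0.29 log units; within the scatter), with the estimate for compound 3 in this assay at 15 nM, ranging from 4 nM to 60 nM.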

Compound 3, half-maximal inhibitory concentration: 63.4 nM
Compound 3: middle estimate off by 4.2-fold (0.63 log units), on the low side, outside the stated range (above it).
By their numbers in this assay, from the lowest: compounds 2, 1 and 3 (each within the scatter of the next, the first and the last beyond it).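

In this assay, the exchange of the ring oxygen for nitrogen at this amine nitrogen gives a 2.2-fold higher number from compound 2 to compound 3 (0.33 log units; beyond the scatter) as a modest step, so the hetero atom of the ring matters here, if only slightly. Against the (oxan-4-yl)methyl group of compound 1, piperidin-4-yl gives a 1.2-fold higher number from compound 1 to compound 3 (0.08 log units; within the scatter) and the two cannot be told apart. Nothing given here accounts for the step. From the compounds shown here alone, it remains open whether a cyclohexyl ring or a 1-methylpiperidin-4-yl group on this amine nitrogen would stand nearer to compound 2 or to compound 3.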